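The source may report more compounds than this note shows. Statements on the series, on what has been measured and on what is new or still open speak of the compounds shown alone.

Measured so far:
Compound 1, `N#CCCN1N=C(c2ccc(OCc3cccc(Cl)c3)cc2)OCC1=O`, gives 13 nM in an assay for inhibition of Amine oxidase [flavin-containing] B (Rattus norvegicus); a lower number here means a stronger inhibitor, a higher number a weaker inhibitor.
Compound 2, `N#CCCN1N=C(c2ccc(OCc3ccc(Cl)cc3)cc2)OCC1=O`, gives 100 nM in this assay.

Compound 2 has the highest number of the two, that is, it is the weaker inhibitor of the pair; the nearest number belongs to compound 1, and the step of a 7.7-fold higher number from compound 1 to compound 2 (0.89 log units; beyond the scatter) separates them, a change beyond the scatter of repeat measurements.

Compound 3, `N#CCCN1N=C(c2ccc(OCc3ccc([N+](=O)[O-])cc3)cc2)OCC1=O`, has not yet been measured in this assay. It differs from compound 2 in one place: nitro in place of chloro on an aromatic carbon. Going by the values given here, the only measured step, a 7.7-fold higher number from compound 1 to compound 2 (0.89 log units; beyond the scatter), concerns moving a chloro group from one ring position to another rather than exchanging it for a different group, so it bears on the present change only indirectly. Among the compounds with values here, no measured pair shows a nitro in place of a chloro. The expectation is therefore a cautious one: a step in this assay from compound 2 to compound 3 with no clear direction, probably not far beyond the scatter, and a wide range to cover the uncertainty. Compound 3 is estimated at 150 nM, within 40 nM to 600 nM. This estimate means an expected step of a 1.5-fold higher number from compound 2 to compound 3 (0.18 log units; within the scatter).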

Compound 3, half-maximal inhibitory concentration: 300 nM
For compound 3 the middle estimate is 2.0-fold (0.30 log units) below the measured one, and the stated range covers the measured number.
By their numbers in this assay, from the lowest: compound 1; then compound 2; then compound 3.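

In this assay the earlier pair only moved a chloro group around the ring, whereas here the group itself changes at one position, para to a large group. Replacing chloro with nitro there gives a 3.0-fold higher number from compound 2 to compound 3 (0.48 log units; beyond the scatter) and so shows that the identity of the group matters at this position, not just where on the ring it sits. Compound 3 is the weakest inhibitor of the three, and the largest gap in the set is a 23-fold higher number from compound 1 to compound 3 (1.36 log units; beyond the scatter) where the 4-nitrophenyl takes the place of the 3-chlorophenyl, combining a change of group with a change of ring position. The data shown offer no measurement that would explain why the nitro group gives the weaker inhibitor.

The compounds shown leave open whether a nitro group would also weaken inhibition in the ring position that chloro holds in compound 1. They also leave open how an amine or a methoxy group would compare with chloro and nitro at the position para to the large group.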